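This account rests on a few compounds, and the source may have more. Where it says the series, first, only, none or still open, it means among the compounds named here.

Measured so far: compound 1 `COc1cc(C(=O)c2ccc3c(ccn3S(=O)(=O)c3ccc(/C=C/C(=O)NO)cc3)c2)cc(OC)c1OC`, compound 2 `COc1cc(C(=O)c2ccc3c(ccn3S(=O)(=O)c3cccc(/C=C/C(=O)NO)c3)c2)cc(OC)c1OC` and compound 3 `COc1ccc(C(=O)c2ccc3c(ccn3Cc3ccc(C(=O)NO)cc3)c2)cc1`.

In an assay on isolated protein for inhibition of polyamine deacetylase HDAC10 (Homo sapiens) (on this read-out lower numbers stand for stronger inhibition and higher numbers for weaker inhibition), compound 1 gives > 100000 nM, which is a limit of the assay and not a number. Compound 2 likewise gives > 100000 nM, again only a limit. Compound 3 gives 59800 nM. The step that the two limits leave unreadable from compound 1 to compound 2 cannot be read, since both of its ends sit at the limit of > 100000 nM in this assay, at which 2 of the 3 values shown sit. Compound 2 therefore stands only at a limit in this assay. Compound 4 `Cc1ccc(C(=O)c2ccc3c(ccn3S(=O)(=O)c3cccc(/C=C/C(=O)NO)c3)c2)cc1` differs from compound 2 by 4-methylphenyl in place of 3,4,5-trimethoxyphenyl on a carbonyl carbon. For the measured compounds named here, no measured step touches this change, and the single readable number, that of compound 3, belongs to a compound that differs in several places at once. Compound 4 is therefore expected to remain weak, with an estimated step of a number no higher from compound 2 to compound 4 (the limit leaves the size open). Compound 4 is estimated at 100000 nM, within 30000 nM to 300000 nM.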

Compound 4, half-maximal inhibitory concentration: 9100 nM
Estimate against measurement, compound 4: 11-fold (1.04 log units) above; the whole stated range lies above it.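

The change to 4-methylphenyl in place of 3,4,5-trimethoxyphenyl on a carbonyl carbon gives an at least 10-fold lower number from compound 2 to compound 4 (1.04 log units; beyond the scatter), which shows that the group at this place can strongly shift the result in this assay. The value of compound 2 is a limit, so the step's true size stays unknown: the limit of > 100000 nM in this assay, at which 2 of the 4 values shown sit.

The compounds shown cannot separate the loss of the methoxy groups from the gain of the methyl group. From the compounds shown here alone, how a plain phenyl or a 4-chlorophenyl would read at this place also stays open.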